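Ring size on the benzylic amine of the shared core

The source may report more compounds than this note shows. Statements on the series, on what has been measured and on what is new or still open speak of the compounds shown alone.

Compound 1 `Oc1c(CN2CCCCC2)ccc2cccnc12` gives 5210 nM; 5130 nM (2 entries) in a functional assay on MES-SA cells (Homo sapiens) for inhibition, with a stated time of 72 h (on this read-out higher numbers stand for weaker inhibition and lower numbers for stronger inhibition), the pair of entries agreeing closely (the several entries of compound 1 in this assay, 5210 nM; 5130 nM (2 entries)). Compound 2 `Oc1c(C(c2cccnc2)N2CCCC2)ccc2cccnc12` gives 40700 nM in this assay, the higher of the numbers shown so far, and has one further entry that carries no single number. Compound 3 `Oc1c(C(c2cccnc2)N2CCCCC2)ccc2cccnc12` is not yet measured. The change is piperidin-1-yl in place of pyrrolidin-1-yl on a saturated chain carbon bound to two aromatic carbons. For the measured compounds named here, no step between measured compounds is known, so the size of this one is open; a modest gain, at or a little beyond the scatter, is expected. The expected step is a 2.0-fold lower number from compound 2 to compound 3 (0.31 log units; beyond the scatter). For compound 3 the estimate is 20000 nM, between 6000 nM and 60000 nM.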

Compound 3, half-maximal inhibitory concentration: 13500 nM
Compound 3: middle estimate off by 1.5-fold (0.17 log units), on the high side; low and high end bracket the measured number.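

On the saturated chain carbon bound to two aromatic carbons, the size of the amine ring registers in this assay: piperidin-1-yl in place of pyrrolidin-1-yl gives a 3.0-fold lower number from compound 2 to compound 3 (0.48 log units; beyond the scatter). This is the first step read in the series, and repeat entries in this assay sit close together, which lends a step of this size some weight: the several entries of compound 1 in this assay, 5210 nM; 5130 nM (2 entries)

With one pair, this remains a single observation and not a trend. Going by these compounds, whether a larger ring such as azepan-1-yl or a ring with an added oxygen such as morpholin-4-yl would continue the change remains open.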